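Methoxyphenyl in place of chlorothiazole on a piperidine sulfonamide

The source may report more compounds than this note shows. Statements on the series, on what has been measured and on what is new or still open speak of the compounds shown alone.

Three piperidine sulfonamides have been tested in an ADME assay on HCT-116 cells (Homo sapiens) for cytotoxicity, read by CellTiter-Glo, with a stated time of 72 h; a lower number here means a stronger inhibitor, a higher number a weaker inhibitor. Compound 1 `CC1CCN(C2CCN(S(=O)(=O)c3cccc4cnccc34)CC2)CC1` reaches only a limit there, giving > 10000 nM. Compound 2 `Cc1nc(Cl)sc1S(=O)(=O)N1CCC(N2CCC(C)CC2)CC1` likewise stops at a limit, with > 10000 nM. Compound 3 `CCCC(=O)N(Cc1ccccc1)C1CCN(S(=O)(=O)c2c(C)cc(C)cc2C)CC1` also ends at a limit, at > 5000 nM. Going by the values given here, compound 2 thus stands among values that are limits alone, as the limit of > 10000 nM in this assay, at which 2 of the 3 values shown sit, and the limit of > 5000 nM in this assay, at which 1 of the 3 values shown sits, show, and no step between measured compounds can be read. Compound 4 `COc1cccc(S(=O)(=O)N2CCC(N3CCC(C)CC3)CC2)c1` differs from compound 2 in one place: 3-methoxyphenyl in place of 2-chloro-4-methyl-1,3-thiazol-5-yl on a sulfonyl sulfur. With nothing but limits to go on, the expectation for this assay is no step beyond the usual scatter, so a step that the limit leaves unreadable from compound 2 to compound 4 is estimated to be slight. Compound 4 is accordingly estimated at 15000 nM, between 6000 nM and 50000 nM.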

Compound 4, half-maximal inhibitory concentration: > 5000 nM
Compound 4 gave a limit, no number; the forecaster's own chance of this, stated with the estimate: 85%; the middle value lies beyond the limit too.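

Going by these compounds alone, compound 2 and compound 4 both end at limits in this assay, so no step between them can be read. The compounds shown leave open whether 3-methoxyphenyl or 2-chloro-4-methyl-1,3-thiazol-5-yl on the sulfonyl sulfur would give an actual number in this assay.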